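Swapping the amide substituent toward a propargyl group

The compounds below may be only part of what the source reports. "The series", "measured", "known", "first", "only" and "open" are said of these compounds alone.

Measured compounds, with their results in an assay on HL-60 cells for agonist activity at vitamin D3 receptor (Homo sapiens), read by microscopy, with a stated time of 96 h; a higher number here means that more compound is needed for the effect, a lower number that less compound is needed:
Compound 1, `CC[C@@H](C)[C@H](NC(=O)c1ccc(C(CC)(CC)c2ccc(OCC(=O)C(C)(C)C)c(C)c2)n1CC)C(=O)OC`, gives 590 nM.
Compound 2, `CCN(CC)CCNC(=O)c1ccc(C(CC)(CC)c2ccc(OCC(=O)C(C)(C)C)c(C)c2)n1CC`, gives 91 nM.
Compound 3, `CCN(CC)CCNC(=O)c1ccc(C(CC)(CC)c2ccc(OCC(O)C(C)(C)C)c(C)c2)n1CC`, gives 110 nM.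

Compound 3 sits second among the three numbers; it lies close to compound 2, as a 1.2-fold higher number from compound 2 to compound 3 (0.08 log units; within the scatter) shows, and well away from compound 1.

Compound 4, `C#CCNC(=O)c1ccc(C(CC)(CC)c2ccc(OCC(O)C(C)(C)C)c(C)c2)n1CC`, has not yet been measured. Its change from compound 3 is ethynyl in place of (diethylamino)methyl on a saturated chain carbon bound to an amide-type nitrogen.

Within the data shown here, only one measured step touches the substituent on the amide nitrogen: a 6.5-fold lower number from compound 1 to compound 2 (0.81 log units; beyond the scatter). That step shows the amide substituent can move the number by a clear margin, but it compared two groups that differ from the propargyl group, so it gives the size of a possible shift rather than its direction. The step from compound 2 to compound 3 concerns a different part of the molecule and does not bear on this change.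

Among the measured compounds shown here, with a loss of the diethylamino portion and no matching measured example, the expectation for compound 4 is a step of a 2.3-fold higher number from compound 3 to compound 4 (0.36 log units; beyond the scatter), which is uncertain, and an estimated value of 250 nM, ranging from 80 nM to 800 nM.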

Compound 4, half-maximal effective concentration: 240 nM
Beside the measured number, compound 4's estimate is 1.0-fold (0.02 log units) above it; low and high end bracket the measured number.
By their numbers in this assay, from the lowest: compounds 2 and 3 (each within the scatter of the next); then compound 4; then compound 1.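

In this assay, among these compounds, the swap of 2-(diethylamino)ethyl for propargyl on the amide nitrogen gives the first reading of this position with the hydroxyl side chain in place, and the result is a modest shift (a 2.2-fold higher number from compound 3 to compound 4 (0.34 log units; beyond the scatter)). Compound 4 carries no diethylamino portion and still gives 240 nM, so in this series the amine is not needed for a response in the nanomolar range, although the number does rise beyond the scatter. No measurement at hand explains the shift.

On these data alone, the amine leaves and the triple bond enters in this single step, so their separate contributions remain open. A plain propyl group or a 2-(dimethylamino)ethyl group on the amide nitrogen could help tell them apart.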